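Swapping the difluorophenyl amide for a benzyl amide

This account rests on a few compounds, and the source may have more. Where it says the series, first, only, none or still open, it means among the compounds named here.

Three compounds share one core and differ only in the group on the amide nitrogen. In an assay on CHO-K1 cells for displacement of a labelled ligand from prostaglandin E2 receptor EP1 subtype (Homo sapiens) (a higher number here means a weaker inhibitor, a lower number a stronger inhibitor), compound 1 `Cc1cc(C(=O)NC(C)C)nn1Cc1cc(Cl)ccc1OCc1ccccc1` gives 126 nM, compound 2 `Cc1cc(C(=O)Nc2ccc(F)cc2)nn1Cc1cc(Cl)ccc1OCc1ccccc1` gives 79.4 nM, and compound 3 `Cc1cc(C(=O)Nc2c(F)cccc2F)nn1Cc1cc(Cl)ccc1OCc1ccccc1` gives 10 nM, the lowest of the three numbers. The steps of a 13-fold lower number from compound 1 to compound 3 (1.10 log units; beyond the scatter) and a 7.9-fold lower number from compound 2 to compound 3 (0.90 log units; beyond the scatter) both show that the 2,6-difluorophenyl group yields a clearly lower number than an isopropyl or a 4-fluorophenyl group. Compound 4 `Cc1cc(C(=O)NCc2ccccc2)nn1Cc1cc(Cl)ccc1OCc1ccccc1` carries the change (benzyl in place of 2,6-difluorophenyl on an amide-type nitrogen). Among the measured compounds shown here, no measured pair shows this exact exchange, but both measured steps toward compound 3 went down, so exchanging its 2,6-difluorophenyl is expected to move the number back up by a modest amount. Compound 4 is therefore expected to give 80 nM in this assay, within 25 nM to 250 nM, a step of an 8.0-fold higher number from compound 3 to compound 4 (0.90 log units; beyond the scatter).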

Compound 4, half-maximal inhibitory concentration: 39.8 nM
For compound 4 the middle estimate is 2.0-fold (0.30 log units) above the measured one; the range from low to high includes it.
By their numbers in this assay, from the lowest: compound 3; then compounds 4, 2 and 1 (each within the scatter of the next, the first and the last beyond it).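

Benzyl is the first group apart from 2,6-difluorophenyl to separate from isopropyl, with a 3.2-fold lower number from compound 1 to compound 4 (0.50 log units; beyond the scatter). It still does not match the 2,6-difluorophenyl group, as a 4.0-fold higher number from compound 3 to compound 4 (0.60 log units; beyond the scatter) shows. Against 4-fluorophenyl, a 2.0-fold lower number from compound 2 to compound 4 (0.30 log units; within the scatter) leaves the two groups indistinguishable, so a ring without fluorine can do as well here as a ring with one.

Nothing available gives a reason for this order. Still open, going by these compounds, is how a 2,6-difluorobenzyl group or a longer chain such as phenethyl would compare on this amide nitrogen.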